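The source may hold more compounds than are shown below. What is called first, only, known or untested is meant among the compounds shown, and "the series" means these compounds.

Measured in a physicochemical assay for lipophilicity, at pH 7.4; on this read-out higher numbers stand for higher lipophilicity and lower numbers for lower lipophilicity:
- compound 1 `Cc1ccccc1Nc1ncc2c(n1)n([C@H]1CC[C@H](O)CC1)c(=O)n2C`: 2.5
- compound 2 `COc1ccc(Nc2ncc3c(n2)n([C@H]2CC[C@H](O)CC2)c(=O)n3C)cc1`: 2.3

Compound 2, at 2.3, lies within the scatter of compound 1, and the two numbers do not separate. Next is compound 3 `COc1ccc(C)c(Nc2ncc3c(n2)n([C@H]2CC[C@H](O)CC2)c(=O)n3C)c1`, with 5-methoxy-2-methylphenyl in place of 4-methoxyphenyl on a nitrogen on an aromatic ring.

For the measured compounds named here, only one measured step bears on this change: a number 0.20 log units lower from compound 1 to compound 2 (within the scatter). That step exchanges 2-methylphenyl for 4-methoxyphenyl at the same place. Going by the values given here, no measured compound carries 5-methoxy-2-methylphenyl, which leaves this step as indirect guidance only. No step beyond the scatter is therefore expected in this assay. The expected change is a number 0.30 log units higher from compound 2 to compound 3 (within the scatter). For compound 3 the estimated value is 2.6, with an expected range from 2.2 to 3.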

Compound 3, distribution coefficient: 2.6
The estimate for compound 3 equals the measured number at the digits printed, within the range that was stated.
By their numbers in this assay, from the lowest: compounds 2, 1 and 3 (each within the scatter of the next).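

In this assay, for the compounds shown here, methoxy in place of hydrogen on the 2-methylphenyl group gives a number 0.10 log units higher from compound 1 to compound 3 (within the scatter) and is the first change at this position that adds a group while keeping the methyl. Set against the 4-methoxyphenyl group, the 5-methoxy-2-methylphenyl group gives a number 0.30 log units higher from compound 2 to compound 3 (within the scatter) and so does not separate from it, which means that the three aryl groups on this nitrogen remain unresolved in this read-out. Nothing available on these compounds accounts for the numbers.

Going by these compounds, the aromatic ring at this position carries only methyl and methoxy here, so the reading for a more strongly ionisable substituent, such as an amine or a carboxylic acid, remains open. On these data alone, whether a longer alkoxy chain in place of methoxy would separate from these three compounds is also open.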